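Arylpiperazine to phenylpropyl chain: a shared core revisited

The source may report more compounds than this note shows. Statements on the series, on what has been measured and on what is new or still open speak of the compounds shown alone.

Three compounds on one shared core were measured. In a functional assay on CHO cells with adenosine receptor A1 (Homo sapiens) as the target, read by cAMP accumulation and immunoassay, with a stated time of 6 min, tested at 1 uM (on this read-out higher numbers stand for a weaker effect at the one concentration tested and lower numbers for a stronger effect), compound 1 `Nc1scc(CN2CCN(c3ccc(F)cc3Cl)CC2)c1C(=O)c1ccc(Cl)cc1` gives -39%, compound 2 `Nc1scc(CN2CCN(c3cccc(C(F)(F)F)c3)CC2)c1C(=O)c1ccc(Cl)cc1` gives -72%, and compound 3 `Nc1scc(CN2CCN(c3ccccc3C(F)(F)F)CC2)c1C(=O)c1ccc(Cl)cc1` gives -39%. Compound 3 stands level with compound 1, and the two together are the highest of the three numbers; the step of no change at the digits printed from compound 1 to compound 3 (within the scatter) is within the scatter, whereas a number 33 percentage points higher from compound 2 to compound 3 (beyond the scatter) is large, as is a number 33 percentage points lower from compound 1 to compound 2 (beyond the scatter). Compound 4 `Nc1scc(CN2CCN(CCCc3ccc(Cl)cc3)CC2)c1C(=O)c1ccc(Cl)cc1` differs from compound 3 in the change (3-(4-chlorophenyl)propyl in place of 2-(trifluoromethyl)phenyl on an amine nitrogen in a ring). Within the data shown here, every measured step exchanges one aryl group for another on the same ring nitrogen; none of them places a chain there, so no measured step bears directly on this change. The aryl swaps moved the read-out either not at all or by a large amount, so the expectation for compound 4 is wide and centred near the measured values. Compound 4 is therefore expected at roughly -45%, within -80% to -10%, a step of a number 6 percentage points lower from compound 3 to compound 4 (within the scatter) that is estimated, not measured.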

Compound 4, a percentage reported as activity, at one concentration (the size of the read-out at that concentration, not a potency): -30%
Estimate against measurement, compound 4: 15 percentage points below, within the range that was stated.
By their numbers in this assay, from the lowest: compound 2; then compounds 1, 3 and 4 (each within the scatter of the next).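

In this assay, the ring nitrogen turns out to accept a chain as well as a directly attached aryl group: with 3-(4-chlorophenyl)propyl in that place the read-out shows a number 9 percentage points higher from compound 3 to compound 4 (within the scatter) and a number 9 percentage points higher from compound 1 to compound 4 (within the scatter) as well. Only the 3-(trifluoromethyl)phenyl group stands apart, with a number 42 percentage points higher from compound 2 to compound 4 (beyond the scatter) in the read-out, so this chain reads with the 2-(trifluoromethyl)phenyl and 2-chloro-4-fluorophenyl groups and does not reach the level of compound 2. Nothing at hand accounts for these steps.

From the compounds shown here alone, whether a shorter or longer chain would change the read-out remains open, as does the effect of a 3-(3-(trifluoromethyl)phenyl)propyl group. A chain carrying an amine or a carboxylic acid in place of the 4-chlorophenyl group is also left open.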